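Benzyloxy variation on the propargyloxy isoflavone core

This account rests on a few compounds, and the source may have more. Where it says the series, first, only, none or still open, it means among the compounds named here.

Measured so far in a functional assay on HCT-116 cells (Homo sapiens) for antiproliferative activity, read by MTT assay, with a stated time of 24 h; on this read-out lower numbers stand for stronger inhibition and higher numbers for weaker inhibition:
compound 1 `C#CCOc1ccc2c(=O)c(-c3cc(OC)c(OC)cc3OC)coc2c1` gives 8050 nM
compound 2 `COc1ccc2c(=O)c(-c3cc(OC)c(OC)cc3OC)coc2c1` gives 9170 nM
compound 3 `COc1cc(OC)c(-c2coc3cc(OCc4ccc(Cl)cc4)ccc3c2=O)cc1OC` gives 4450 nM

Compound 1 holds the second highest number of the three. Its nearest neighbour is compound 2, reached by a step of a 1.1-fold higher number from compound 1 to compound 2 (0.06 log units; within the scatter), and its furthest is compound 3, reached by a step of a 1.8-fold lower number from compound 1 to compound 3 (0.26 log units; within the scatter); both of these steps stay within the scatter, so the three values are not separable.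

Compound 4 `COc1cc(OC)c(-c2coc3cc(OCc4ccccc4Br)ccc3c2=O)cc1OC` differs from compound 1 by 2-bromophenyl in place of ethynyl on a saturated chain carbon bound to an oxygen on an aromatic ring. For the measured compounds named here, the step that bears most directly on this change is the one from compound 1 to compound 3, which replaces the same ethynyl with an aryl group and moves the number by a 1.8-fold lower number from compound 1 to compound 3 (0.26 log units; within the scatter). The related step from compound 2 to compound 3, a 2.1-fold lower number from compound 2 to compound 3 (0.31 log units; beyond the scatter), is modest. Both point the same way, downward, but only weakly.

Compound 4 is therefore expected to sit close to compound 3, with a step of about a 1.6-fold lower number from compound 1 to compound 4 (0.21 log units; within the scatter). The estimate for compound 4 is 5000 nM, within 2500 nM to 10000 nM.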

Compound 4, half-maximal inhibitory concentration: 4550 nM
Beside the measured number, compound 4's estimate is 1.1-fold (0.04 log units) above it; the measured number falls inside the stated range.
By their numbers in this assay, from the lowest: compounds 3, 4, 1 and 2 (each within the scatter of the next, the first and the last beyond it).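

In this assay, 2-bromophenyl and 4-chlorophenyl are not told apart on the saturated chain carbon bound to an oxygen on an aromatic ring (a 1.0-fold higher number from compound 3 to compound 4 (0.01 log units; within the scatter)). Compound 4 also stays within the scatter of the ethynyl compound (a 1.8-fold lower number from compound 1 to compound 4 (0.25 log units; within the scatter)) and of the compound with hydrogen at this place (a 2.0-fold lower number from compound 2 to compound 4 (0.30 log units; within the scatter)). Compound 3 therefore remains the only compound with a step beyond the scatter, and that step is modest, so the two aryl groups shown give no clear separation from either smaller group.

Going by these compounds, whether a benzyl group carrying an amine or a carboxylic acid, or a longer chain in place of propargyl, would give a larger step remains open. No supporting data bear on why these values fall as they do.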